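The source may hold more compounds than are shown below. What is called first, only, known or untested is meant among the compounds shown, and "the series" means these compounds.

Compound 1, with the structure `CC1(C)CCN(S(=O)(=O)c2ccc(NC(=O)c3ccc([N+](=O)[O-])o3)cc2)CC1`, is the starting point of this account. In an ADME assay on IMR-90 cells (Homo sapiens) for cytotoxicity, read by CellTiter-Blue, with a stated time of 46 h (on this read-out higher numbers stand for an effect only at larger amounts of compound and lower numbers for an effect already at smaller amounts), compound 1 gives > 25000 nM, which is a limit of the assay rather than a number, so compound 1 stands only at a bound on the numbers shown. Two related compounds sit at the same bound. Compound 2, with the structure `O=C(Nc1ccc(S(=O)(=O)N2CCC(Cl)CC2)cc1)c1ccc([N+](=O)[O-])o1`, gives > 25000 nM in this assay, again a limit and not a number. Compound 3, with the structure `O=C(Nc1ccc(S(=O)(=O)C2CCCCC2)cc1)c1ccc([N+](=O)[O-])o1`, gives > 25000 nM in this assay, also a limit. Accordingly the steps among them, a step that the two limits leave unreadable from compound 1 to compound 2, a step that the two limits leave unreadable from compound 1 to compound 3 and a step that the two limits leave unreadable from compound 2 to compound 3, cannot be read in size or direction, which is summed up by the limit of > 25000 nM in this assay, at which 3 of the 3 values shown sit.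

The compound not yet measured is compound 4, with the structure `O=C(Nc1ccc(S(=O)(=O)c2ccccc2)cc1)c1ccc([N+](=O)[O-])o1`. It differs from compound 1 by phenyl in place of 4,4-dimethylpiperidin-1-yl on a sulfonyl sulfur. None of the three measured steps exchanges the group on the sulfonyl sulfur for an aromatic ring, and all three remain unreadable, so the step that the limit leaves unreadable from compound 1 to compound 4 from compound 1 to compound 4 is expected to show nothing beyond the scatter. Compound 4 is therefore estimated at 30000 nM in this assay, with a range from 12000 nM to 80000 nM, and most likely reported only as a limit.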

Compound 4, half-maximal effective concentration: > 25000 nM
Compound 4: only a limit was reported; the forecaster's own chance of this, stated with the estimate: 75%; the middle value is on the limit's open side.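

Compound 4 joins compounds 1, 2 and 3 at a limit rather than a number, so the steps to compound 4 from compounds 1, 2 and 3 cannot be read in size or direction: the limit of > 25000 nM in this assay, at which 4 of the 4 values shown sit.

The compounds shown leave open how far apart these four lie in this assay, and whether any exchange on the sulfonyl sulfur changes the read-out at all.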